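A few compounds are considered here, and "the series" means these few. Any claim that something is new, unique, unknown or untested is made for them only; others in the source may bear on it.

In a functional assay on MCF7 cells (Homo sapiens) for antiproliferative activity, read by MTT assay, with a stated time of 48 h (on this read-out higher numbers stand for weaker inhibition and lower numbers for stronger inhibition), compound 3 `CCn1c(C(=O)N(C)CCO)ccc1C(CC)(CC)c1ccc(OCCC(O)(CC)CC)c(C)c1` gives 2870 nM. Compound 1 `CCn1c(C(=O)NCCCN(C)C)ccc1C(CC)(CC)c1ccc(OCCC(O)(CC)CC)c(C)c1` gives 3350 nM, and a 1.2-fold lower number from compound 1 to compound 3 (0.07 log units; within the scatter) leaves the two level, so compound 3 stands with compound 1 at the active end of the three. Compound 2 `C=CCN(C)C(=O)c1ccc(C(CC)(CC)c2ccc(OCCC(O)(CC)CC)c(C)c2)n1CC` reads > 50000 nM, which is a limit of this assay and not a number. Exchanges on the same carbonyl carbon also gave an at least 14-fold higher number from compound 1 to compound 2 (1.17 log units; beyond the scatter) and an at least 17-fold lower number from compound 2 to compound 3 (1.24 log units; beyond the scatter), both large, and both rest on (the limit of > 50000 nM in this assay, at which 1 of the 3 values shown sits).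

Compound 4 `CCn1c(C(=O)NC(CO)CCO)ccc1C(CC)(CC)c1ccc(OCCC(O)(CC)CC)c(C)c1` carries a group of 7 heavy atoms (4 carbon, 1 nitrogen, 2 oxygen; no ring) in place of a group of 5 heavy atoms (3 carbon, 1 nitrogen, 1 oxygen; no ring), on a carbonyl carbon. Neither group has a ring or a net charge. The entering group keeps oxygen, as the leaving group does, and compound 4 has no allyl(methyl)amino, the group of compound 2. The expectation therefore follows the small step between compound 1 and compound 3, with compound 2 as the warning against it. In this assay the expected change is a 1.2-fold higher number from compound 3 to compound 4 (0.09 log units; within the scatter), with no shift beyond the scatter. The estimate for compound 4 is 3500 nM, with an expected range of 1200 nM to 12000 nM.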

Compound 4, half-maximal inhibitory concentration: 31400 nM
The estimate for compound 4 lay 9.0-fold (0.95 log units) below the measured number; the whole stated range lies below it.
By their numbers in this assay, from the lowest: compounds 3 and 1 (each within the scatter of the next); then compound 4. At a limit, above all of these: compound 2.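

In this assay, oxygen in the group on this carbonyl carbon does not by itself hold the number level: the group of 7 heavy atoms in place of (2-hydroxyethyl)(methyl)amino gives an 11-fold higher number from compound 3 to compound 4 (1.04 log units; beyond the scatter). The level pair of compound 1 and compound 3 therefore does not extend to every group here, and 3-hydroxy-1-(hydroxymethyl)propyl in place of 3-(dimethylamino)propyl on the amide-type nitrogen gives a 9.4-fold higher number from compound 1 to compound 4 (0.97 log units; beyond the scatter). With an at least 1.5-fold lower number from compound 2 to compound 4 (0.20 log units; that floor lies within the scatter), compound 4 cannot be set apart from compound 2, whose reading is a limit and not a number: the limit of > 50000 nM in this assay, at which 1 of the 4 values shown sits.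

The compounds shown do not separate the branching of the entering group from its second hydroxyl or from the amide hydrogen. As far as these compounds go, an unbranched 3-hydroxypropyl amide, a morpholine amide and a carboxylic acid on this chain remain open.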